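From Fluoro-methoxyphenyl to Hydroxyphenyl on the Shared Core

The source may hold more compounds than are shown below. What is called first, only, known or untested is meant among the compounds shown, and "the series" means these compounds.

Going by the values given here, compound 1 `COc1ccc(-c2nc3cccc(-c4cc(OC)c(OC)c(OC)c4)c3o2)cc1F` is one of two compounds measured in a functional assay on A549 cells (Homo sapiens) for antiproliferative activity, read by MTT assay, with a stated time of 48 h (on this read-out lower numbers stand for stronger inhibition and higher numbers for weaker inhibition), and in that assay compound 1 gives 1800 nM. Among the compounds with values here, its only neighbour is compound 2 `COc1cc(-c2cccc3nc(-c4cccc(Br)c4)oc23)cc(OC)c1OC`, which in this assay gives 2100 nM; the step of a 1.2-fold higher number from compound 1 to compound 2 (0.07 log units; within the scatter) shows that exchanging the aryl group on that carbon for 3-bromophenyl left the read-out inside the scatter, so no order between the two can be claimed. Compound 3 `COc1cc(-c2cccc3nc(-c4cccc(O)c4)oc23)cc(OC)c1OC` is not yet measured; it differs from compound 1 by 3-hydroxyphenyl in place of 3-fluoro-4-methoxyphenyl on an aromatic carbon. Within the data shown here, the one step that bears on this position, a 1.2-fold higher number from compound 1 to compound 2 (0.07 log units; within the scatter), was within the scatter, and no measured step covers a 3-hydroxyphenyl, so the expectation rests on that single tolerance. Compound 3 is therefore expected to lie near compound 1, with a 1.1-fold lower number from compound 1 to compound 3 (0.05 log units; within the scatter) expected to stay within the scatter. The estimate for compound 3 is 1600 nM, in a range from 500 nM to 5000 nM.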

Compound 3, half-maximal inhibitory concentration: 2000 nM
The estimate for compound 3 lay 1.3-fold (0.10 log units) below the measured number; the range from low to high includes it.
By their numbers in this assay, from the lowest: compounds 1, 3 and 2 (each within the scatter of the next).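

In this assay, the step of a 1.1-fold higher number from compound 1 to compound 3 (0.05 log units; within the scatter) exchanges 3-fluoro-4-methoxyphenyl for the smaller 3-hydroxyphenyl, a group with a hydrogen-bond donor, and the read-out stays within the scatter. The step of a 1.1-fold lower number from compound 2 to compound 3 (0.02 log units; within the scatter), hydroxy in place of bromo, also stays within the scatter, so the three aryl groups shown at this position on the shared core give values that cannot be ordered, and the tolerance suggested by the earlier pair now extends to a hydroxy-bearing ring. Nothing available accounts for this tolerance.

The compounds shown leave open whether it would hold for an amine or a carboxylic acid on the phenyl ring, or for a longer chain in place of that ring. As far as these compounds go, whether the same holds outside this single cell read-out also stays open.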